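This account rests on a few compounds, and the source may have more. Where it says the series, first, only, none or still open, it means among the compounds named here.

Measured compounds:
- compound 1, `Fc1cc(/C=C/c2cc(OC[C@@H]3CCN3)cnc2Cl)ccn1`, in an assay on membranes from brain with Neuronal acetylcholine receptor; alpha4/beta2 (Rattus norvegicus) as the target (on this read-out lower numbers stand for stronger inhibition and higher numbers for weaker inhibition), compound 1 gives 0.0031 nM
- compound 2, `Clc1ncc(OC[C@@H]2CCN2)cc1/C=C/c1ccnc(Br)c1`, in this assay compound 2 gives 0.0052 nM

Compound 1 has the lowest of the two numbers in this assay; its nearest neighbour is compound 2, and the step of a 1.7-fold higher number from compound 1 to compound 2 (0.22 log units; within the scatter) lies within the scatter, so the two cannot be set in order. That step concerns the halogen on the aromatic carbon and leaves the remainder of the molecule untouched.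

Compound 3, `Fc1cc(/C=C/c2cc(OC[C@@H]3CCCN3)cnc2Cl)ccn1`, has not yet been measured in this assay. It differs from compound 1 by pyrrolidin-2-yl in place of azetidin-2-yl on a saturated chain carbon bound to an oxygen on an aromatic ring. Among the compounds with values here, no measured step in this assay touches that part of the shared core; the only step known, from compound 1 to compound 2, concerns another position and therefore gives no guidance on the size or direction of this change. With nothing to go on beyond the two values in hand, the expectation for compound 3 is a number near that of compound 1, with a wide range on either side to cover a possible weakening or strengthening. Compound 3 is estimated at 0.006 nM, within 0.002 nM to 0.03 nM. This estimate means a step of a 1.9-fold higher number from compound 1 to compound 3 (0.29 log units; within the scatter), which is expected to fall within the scatter.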

Compound 3, inhibition constant: 0.0094 nM
Beside the measured number, compound 3's estimate is 1.6-fold (0.19 log units) below it; the measured number falls inside the stated range.
By their numbers in this assay, from the lowest: compounds 1, 2 and 3 (each within the scatter of the next, the first and the last beyond it).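

In this assay, this place on the saturated chain carbon bound to an oxygen on an aromatic ring proves sensitive to the change from the four-membered ring to the five-membered ring: pyrrolidin-2-yl in place of azetidin-2-yl gives a 3.0-fold higher number from compound 1 to compound 3 (0.48 log units; beyond the scatter) and so moves the number by a modest step. Within the data shown here, the only earlier step, bromo in place of fluoro, gave a 1.7-fold higher number from compound 1 to compound 2 (0.22 log units; within the scatter) and could not set its two compounds in order, so this is the first change that can be read as a real difference, and it favours azetidin-2-yl over pyrrolidin-2-yl. Nothing available explains why the number moves with this exchange.

The compounds shown leave open how piperidin-2-yl, or an open chain such as 2-aminoethyl, would read at this same place, and so whether the number keeps rising as the ring grows. They also leave open whether the step from azetidin-2-yl to pyrrolidin-2-yl would keep its size with bromo in place of fluoro on the aromatic carbon, or with the opposite configuration at the defined stereocentre.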